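The compounds below may be only part of what the source reports. "The series", "measured", "known", "first", "only" and "open" are said of these compounds alone.

Of the compounds shown here, three have been tested, and a fourth remains open. Compound 1 `Cc1cccc(/C=C2\Cc3ccccc3C2=O)c1` and compound 2 `COc1cccc(/C=C2\Cc3ccccc3C2=O)c1` share one core, while compound 3 `Cc1cccc(/C=C2\CCCCCC2=O)c1` and compound 4 `COc1cccc(/C=C2\CCCCCC2=O)c1` share another; how the two cores differ is not broken down here.

In a functional assay on P388 cells (Mus musculus) for inhibition (on this read-out higher numbers stand for weaker inhibition and lower numbers for stronger inhibition), compound 1 gives 24900 nM. Compound 3 gives 29800 nM in this assay, which sits within the scatter of compound 1. Compound 2 reaches > 50000 nM in this assay, which is a limit of the assay and not a number.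

The change from compound 1 to compound 2 is methoxy in place of methyl on an aromatic carbon. That step, an at least 2.0-fold higher number from compound 1 to compound 2 (0.30 log units; that floor lies within the scatter), can only be read as a floor, because its upper end is hidden by the limit of > 50000 nM in this assay, at which 1 of the 3 values shown sits.

The change from compound 3 to compound 4 is methoxy in place of methyl on an aromatic carbon. It is the same kind of change: in compound 1 the place is described as meta to a large group, in compound 3 as meta to a group of 9 heavy atoms. Since compound 3 starts from 29800 nM, close to where compound 1 starts, a step of similar size is expected, a 2.2-fold higher number from compound 3 to compound 4 (0.34 log units; beyond the scatter). There is a real chance that compound 4 will also be reported only as a limit. Compound 4 is expected to give about 65000 nM in this assay, most likely between 30000 nM and 160000 nM.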

Compound 4, half-maximal inhibitory concentration: 50000 nM
The estimate for compound 4 lay 1.3-fold (0.11 log units) above the measured number, within the range that was stated.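

In this assay, methoxy in place of methyl on an aromatic carbon gives a 1.7-fold higher number from compound 3 to compound 4 (0.22 log units; within the scatter), so on this core the effect of the change cannot be told apart from the ordinary spread of repeated measurements. Neither this step nor the earlier one stands clear of that spread, which means the pair gives no sign that the change behaves differently on the two cores, but it also gives no proof that it behaves alike, and whether the change carries over stays unsettled: the same change on two cores in this assay, an at least 2.0-fold higher number (0.30 log units; that floor lies within the scatter) from compound 1 to compound 2 and a 1.7-fold higher number (0.22 log units; within the scatter) from compound 3 to compound 4; the limit leaves it open whether they differ The earlier step is known only as a floor, so its true size cannot be set against the new one, since one value in the series is a limit of the assay and not a number: the limit of > 50000 nM in this assay, at which 1 of the 4 values shown sits.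

The compounds shown carry only methyl or methoxy at this place on the aromatic ring, so it remains open how a hydroxyl, an amine or a carboxylic acid there would read in this assay. As far as these compounds go, two cores are also a narrow base, and it remains open whether the same swap would give a step of similar size on a third core, or whether any group at this place would give clearly stronger inhibition.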